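Trifluoromethyl in Place of Hydrogen on the Five-Membered Ring

The compounds below may be only part of what the source reports. "The series", "measured", "known", "first", "only" and "open" are said of these compounds alone.

Compound 1 `CCCC(Oc1ccc(-n2cc(F)cn2)cc1)c1ccc(C(=O)NCCC(=O)O)cc1`: 10000 nM
Compound 2 `CCCC(Oc1ccc(-n2cccn2)cc1)c1ccc(C(=O)NCCC(=O)O)cc1`: > 55000 nM

In a functional assay on cells for antagonist activity at Glucagon receptor (Homo sapiens), read by cAMP accumulation, in the presence of a further agent that is not named here (a lower number here means a stronger inhibitor, a higher number a weaker inhibitor), compound 1 gives 10000 nM. Compound 2 reaches only a limit of this assay and no number, namely > 55000 nM; this is the limit of > 55000 nM in this assay, at which 1 of the 2 values shown sits. The change between them is an at least 5.5-fold higher number from compound 1 to compound 2 (0.74 log units; beyond the scatter), so compound 2 stands at the weak end of what has been measured, with its true value unknown beyond that limit.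

Compound 3 `CCCC(Oc1ccc(-n2cc(C(F)(F)F)cn2)cc1)c1ccc(C(=O)NCCC(=O)O)cc1` has not yet been measured. It differs from compound 2 by trifluoromethyl in place of hydrogen on an aromatic carbon. Among the measured compounds shown here, the only measured step that bears on this is the one from compound 1 to compound 2, where removing fluoro weakened inhibition beyond the scatter; adding a larger fluorine-bearing group at the same carbon is therefore expected to move this assay back toward a measurable number, though the size of that move cannot be fixed from a limit. Compound 3 is expected to give about 6000 nM in this assay. For compound 3 the estimated range runs from 1500 nM to 40000 nM. This estimate amounts to an at least 9.1-fold lower number from compound 2 to compound 3 (0.96 log units; beyond the scatter).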

Compound 3, antagonist equilibrium constant: 5100 nM
Estimate against measurement, compound 3: 1.2-fold (0.07 log units) above; measured number inside the range.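

Trifluoromethyl on this carbon of the five-membered ring also brings back a measurable number in this assay, with an at least 10-fold lower number from compound 2 to compound 3 (1.03 log units; beyond the scatter). As far as these compounds go, compound 2 gives a limit and not a number, so the true size of that step stays unknown: the limit of > 55000 nM in this assay, at which 1 of the 3 values shown sits. Fluoro and trifluoromethyl at this carbon cannot be told apart in this assay, with a 2.0-fold lower number from compound 1 to compound 3 (0.29 log units; within the scatter), so in compound 1 and compound 3 the recovery is not tied to a single fluorine-bearing group.

From the compounds shown here alone, whether a chloro, a methyl or a nitrile on this carbon would serve equally well remains open, so the need for fluorine itself cannot be judged. Also open, going by these compounds, is whether any group here could bring inhibition far beyond that of compound 1 and compound 3.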